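The compounds below may be only part of what the source reports. "The series", "measured", "known", "first", "only" and "open" are said of these compounds alone.

Working notes on the series. In a functional assay on NUGC-3 cells (Homo sapiens) for cytotoxicity, read by sulforhodamine B assay, with a stated time of 72 h (on this read-out higher numbers stand for weaker inhibition of growth and lower numbers for stronger inhibition of growth), compound 3 `O=C(Nc1ccccc1O)C1CCc2ccccc2N1C(=O)c1ccccc1` gives 3780 nM, the lowest of the three numbers: compound 1 `O=C(Nc1ccccc1O)C1CCc2ccccc2N1C(=O)c1ccccc1Cl` gives 36800 nM and compound 2 `O=C(Nc1ccccc1C(F)(F)F)C1CCc2ccccc2N1` gives 39300 nM. For the measured compounds named here, the only measured step, a 9.7-fold lower number from compound 1 to compound 3 (0.99 log units; beyond the scatter), concerns a substituent on the benzoyl and not the ring nitrogen itself. Compound 4 `O=C(Nc1ccccc1O)C1CCc2ccccc2N1` differs from compound 3 by hydrogen in place of benzoyl on a nitrogen on an aromatic ring in a ring. Going by the values given here, no measured pair shows this change directly; compound 2, which also carries nothing on that nitrogen, gives 39300 nM, but it differs from compound 4 elsewhere as well, so only a loose reading is possible. On that basis compound 4 is expected to give a higher number, with a step of a 5.3-fold higher number from compound 3 to compound 4 (0.72 log units; beyond the scatter). The estimate for compound 4 is 20000 nM, with a range from 4000 nM to 80000 nM.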

Compound 4, concentration for 50% growth inhibition: 2680 nM
Beside the measured number, compound 4's estimate is 7.5-fold (0.87 log units) above it; measured number outside the range, below it.
By their numbers in this assay, from the lowest: compounds 4 and 3 (each within the scatter of the next); then compounds 1 and 2 (each within the scatter of the next).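

In this assay the step of a 1.4-fold lower number from compound 3 to compound 4 (0.15 log units; within the scatter) lies within the scatter, so hydrogen and benzoyl on this nitrogen cannot be told apart here. The chloro-bearing acyl group does stand apart from hydrogen, with a 14-fold lower number from compound 1 to compound 4 (1.14 log units; beyond the scatter) beyond the scatter. With nothing on that nitrogen, a 15-fold lower number from compound 2 to compound 4 (1.17 log units; beyond the scatter) shows that hydroxy in place of trifluoromethyl on an aromatic carbon also counts. No measured evidence on the cause of these steps is available. Open, going by these compounds, is whether an acetyl group or a longer acyl chain on this nitrogen, or an amine in place of hydroxy, would give a similar number.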